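Acylation of a Bicyclic Diol: Expected Cytotoxicity Shift

A few compounds are considered here, and "the series" means these few. Any claim that something is new, unique, unknown or untested is made for them only; others in the source may bear on it.

Measured compounds:
compound 1 `CC(=O)O[C@]12C=CC(=O)C[C@H]1OCC2`, 0.5 ug/mL
compound 2 `O=C1C=C[C@]2(OC(=O)c3ccc(Cl)cc3)CCO[C@@H]2C1`, 0.7 ug/mL
compound 3 `OC1C=C[C@]2(O)CCO[C@@H]2C1`, 40.8 ug/mL

In a functional assay on P388 cells (Mus musculus) for cytotoxicity (a higher number here means a weaker inhibitor, a lower number a stronger inhibitor), compound 3 gives 40.8 ug/mL, the highest number of the three; compound 2 sits far lower at 0.7 ug/mL and compound 1 lower still at 0.5 ug/mL, both gaps beyond the scatter. Compound 4 `CC(=O)O[C@]12C=CC(O)C[C@H]1OCC2` is not yet measured. It differs from compound 3 in one place: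

acetyl in place of hydrogen on an oxygen on a saturated carbon

Among the measured compounds shown here, no measured pair carries exactly this change, so the step is judged from the spread alone. For compound 4 the step of a 5.1-fold lower number from compound 3 to compound 4 (0.71 log units; beyond the scatter) is expected to lower the number by a clear margin, short of compound 1. The estimate for compound 4 is 8 ug/mL, within 2 ug/mL to 30 ug/mL.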

Compound 4, half-maximal inhibitory concentration: > 100 ug/mL
Compound 4 gave a limit, no number; the forecaster's own chance of this, stated with the estimate: 5%; middle value at least 12-fold (1.09 log units) away from the limit.
By their numbers in this assay, from the lowest: compounds 1 and 2 (each within the scatter of the next); then compound 3. At a limit, above all of these: compound 4.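

In this assay, acetyl in place of hydrogen on this oxygen does not lower the number, and the change reads as an at least 2.4-fold higher number from compound 3 to compound 4 (0.38 log units; beyond the scatter). Compound 4 stands at a limit, not a number: the limit of > 100 ug/mL in this assay, at which 1 of the 4 values shown sits. Compound 4 carries the acetoxy group of compound 1 but a hydroxy where compound 1 has a carbonyl, so acetoxy alone does not account for the low number of compound 1, 0.5 ug/mL.

Still open, on these data alone, is how the carbonyl counterpart of compound 3 reads in this assay. Also open, as far as these compounds go, is whether a hexanoyl chain or an amine-bearing acyl group on this oxygen follows acetyl.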